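The source may hold more compounds than are shown below. What is called first, only, known or untested is meant among the compounds shown, and "the series" means these compounds.

Measured compounds: compound 1 `O=C(CSc1nnc(-c2ccncc2)o1)N/N=C/c1ccc([N+](=O)[O-])cc1` gives 25800 nM in a functional assay on SW 1116 cells (Homo sapiens) for cytotoxicity, read by MTT assay, with a stated time of 48 h; on this read-out higher numbers stand for weaker inhibition and lower numbers for stronger inhibition; compound 2 `O=C(CSc1nnc(-c2ccncc2)o1)N/N=C/c1cc(Cl)ccc1O` gives 5240 nM in this assay.

Among these two numbers compound 2 stands lowest, and the step of a 4.9-fold lower number from compound 1 to compound 2 (0.69 log units; beyond the scatter) sets it apart from compound 1. Compound 3 `O=C(CSc1nnc(-c2ccncc2)o1)N/N=C/C=C/c1ccccc1` is not yet measured. It differs from compound 2 by 2-phenylethenyl in place of 5-chloro-2-hydroxyphenyl on a carbon with a double bond to nitrogen. No measured step describes this exchange: the one step shown concerns 5-chloro-2-hydroxyphenyl against 4-nitrophenyl, a swap of one aromatic group for another that lowered the number. The shown change removes that group entirely and brings a group without the hydrogen-bond donor and acceptor, so the direction is unknown. Compound 3 is therefore expected to lose part of the gain compound 2 holds over compound 1, with a 2.3-fold higher number from compound 2 to compound 3 (0.36 log units; beyond the scatter) as a modest rise. Compound 3 is estimated at 12000 nM, within a range from 4000 nM to 40000 nM.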

Compound 3, half-maximal inhibitory concentration: 14900 nM
Estimate against measurement, compound 3: 1.2-fold (0.09 log units) below; measured number inside the range.
By their numbers in this assay, from the lowest: compound 2; then compounds 3 and 1 (each within the scatter of the next).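

In this assay, putting 2-phenylethenyl in place of 5-chloro-2-hydroxyphenyl on a carbon with a double bond to nitrogen gives a 2.8-fold higher number from compound 2 to compound 3 (0.45 log units; beyond the scatter) and so does not keep the lower number of compound 2. The same group set against 4-nitrophenyl gives a 1.7-fold lower number from compound 1 to compound 3 (0.24 log units; within the scatter) and leaves these two groups unresolved on this read-out, so that among the three groups shown only 5-chloro-2-hydroxyphenyl stands apart. Nothing in the data at hand gives a reason for these differences.

The compounds shown leave open whether the hydroxyl or the chlorine goes with the lower number of compound 2, which a plain 2-hydroxyphenyl or 3-chlorophenyl group at this place could separate. They also leave open how a saturated 2-phenylethyl chain would compare with 2-phenylethenyl.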